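The source may hold more compounds than are shown below. What is called first, only, known or untested is meant among the compounds shown, and "the series" means these compounds.

Working notes on the series.

In a functional assay on OVCAR-3 cells (Homo sapiens) for inhibition, read by CCK-8 assay, with a stated time of 72 h, tested at 20 uM (a lower number here means less inhibition of growth, a higher number more inhibition of growth at the concentration tested), compound 1 `CC(C)(C)OC(=O)/C=C1/C(=O)Nc2ccccc21` gives 59.6%. Compound 2 `CC(C)(C)OC(=O)/C=C1/C(=O)N(Cc2ccccc2)c2ccccc21` gives 58.9% in this assay, and compound 3 `COc1ccc2c(c1)NC(=O)/C2=C/C(=O)OC(C)(C)C` gives 57.9%. The three numbers sit within the scatter of one another; on the bare figures the number of compound 1 is the highest of the three, with compound 2 nearest and compound 3 furthest. The two single-point changes recorded so far are a number 0.7 percentage points lower from compound 1 to compound 2 (within the scatter), a benzyl in place of hydrogen on an amide-type nitrogen in a ring, and a number 1.7 percentage points lower from compound 1 to compound 3 (within the scatter), a methoxy in place of hydrogen on an aromatic carbon. Neither moves the number beyond the scatter.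

Compound 4 `CC(C)(C)OC(=O)/C=C1/C(=O)Nc2ccc(OC(F)(F)F)cc21` differs from compound 1 by trifluoromethoxy in place of hydrogen on an aromatic carbon. The step from compound 1 to compound 3 bears most directly on it, as it is likewise a substituent entering at an aromatic carbon of the shared core, and it was within the scatter; the step from compound 1 to compound 2, at the ring nitrogen, was also within the scatter. No step beyond the scatter is therefore expected in this assay for compound 4. The expected step is a number 2.6 percentage points lower from compound 1 to compound 4 (within the scatter). Compound 4 is estimated at 57%, with a range of 45% to 68%.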

Compound 4, percent growth inhibition at one concentration: 59%
Compound 4: middle estimate off by 2 percentage points, on the low side, and the stated range covers the measured number.
By their numbers in this assay, from the lowest: compounds 3, 2, 4 and 1 (each within the scatter of the next).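

The trifluoromethoxy group, with 5 heavy atoms including 3 fluorine, enters on an aromatic carbon meta to a fused ring and para to a fused ring, and a number 0.6 percentage points lower from compound 1 to compound 4 (within the scatter) stays within the scatter in this assay at this position. Taken with a number 1.7 percentage points lower from compound 1 to compound 3 (within the scatter) for methoxy on an aromatic carbon, this gives two substituents on aromatic carbons of the shared core whose steps from compound 1 are both within the scatter, and no compound shown goes against this. Compound 3 and compound 4 differ in more than one place. They are not compared directly here. No measurement shown bears on why this change leaves the number within the scatter.

Still open, as far as these compounds go, is whether an amine or a carboxylic acid on this same aromatic carbon would also remain within the scatter of compound 1, since the two groups entering on aromatic carbons here both attach through oxygen. Also open, from the compounds shown here alone, is whether a change at the ester, such as a longer chain in place of the present alkyl group, would produce a step beyond the scatter.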